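A few compounds are considered here, and "the series" means these few. Any claim that something is new, unique, unknown or untested is made for them only; others in the source may bear on it.

In a physicochemical assay for solubility, measured as kinetic solubility, at pH 6.5 (a higher number here means a more soluble compound, a lower number a less soluble compound), compound 1 `COc1ccc(-c2ccc3nnc([C@@H](C)c4ccc5ncccc5c4)n3n2)cc1F` gives 10900 nM and compound 2 `Cc1cccc(-c2ccc3nnc([C@@H](C)c4ccc5ncccc5c4)n3n2)c1` gives 19000 nM in the same test, so compound 2 stands level with compound 1 within the scatter. Compound 3 `C[C@@H](c1ccc2ncccc2c1)c1nnc2ccc(-c3ccccc3C#N)nn12` differs from compound 2 in one place: 2-cyanophenyl in place of 3-methylphenyl on an aromatic carbon puts 2-cyanophenyl in place of 3-methylphenyl. Going by the values given here, the only measured step that bears on this, a 1.7-fold higher number from compound 1 to compound 2 (0.24 log units; within the scatter), exchanged the group on that same aromatic carbon, and it is one small step to go on. No change beyond the scatter is therefore expected in this assay here, and the estimated step is a 1.3-fold lower number from compound 2 to compound 3 (0.10 log units; within the scatter) at most in size. For compound 3 the expected value is 15000 nM, with an estimated range of 5000 nM to 45000 nM around it.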

Compound 3, solubility: 213000 nM
Estimate against measurement, compound 3: 14-fold (1.15 log units) below, and the stated range ends below it.
By their numbers in this assay, from the lowest: compounds 1 and 2 (each within the scatter of the next); then compound 3.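

In this assay the group on this aromatic carbon can matter a great deal: putting 2-cyanophenyl there gives an 11-fold higher number from compound 2 to compound 3 (1.05 log units; beyond the scatter) and a 20-fold higher number from compound 1 to compound 3 (1.29 log units; beyond the scatter), whereas 3-methylphenyl and 3-fluoro-4-methoxyphenyl stood within the scatter of each other. So the two earlier compounds gave no sign of how far this position can move the read-out. Nothing available explains the jump. As far as these compounds go, it remains open whether the nitrile itself carries this step or whether its place on the ring matters. Also open, from the compounds shown here alone, is how an unsubstituted phenyl, or a ring bearing an amine or a carboxylic acid, would compare.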